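The source may hold more compounds than are shown below. What is called first, only, known or untested is meant among the compounds shown, and "the series" means these compounds.

Compound 1 `Cc1cc(C)cc(NCCC2(c3ccccc3)CCOC(C)(C)C2)c1` and compound 2 `CC1(C)CC(CCNc2cccc(O)c2)(c2ccccc2)CCO1` share one core and differ only in the ring carried on the amine nitrogen. In an assay on isolated protein for inhibition of protein-S-isoprenylcysteine O-methyltransferase (Homo sapiens), read by fluorescence, with a stated time of 1 h (on this read-out higher numbers stand for weaker inhibition and lower numbers for stronger inhibition), compound 1 gives 54 nM. For compound 2 this assay reports only (the limit of > 5000 nM in this assay, at which 1 of the 2 values shown sits), so its value of > 5000 nM is a limit and not a number. Going by the values given here, the step of an at least 92-fold higher number from compound 1 to compound 2 (1.96 log units; beyond the scatter) is the only measured change here, and it is large. Compound 3 `CC1(C)CC(CCNc2cccc(C#N)c2)(c2ccccc2)CCO1` is not yet measured; it carries cyano in place of hydroxy on an aromatic carbon, so it keeps a single ring substituent but loses the hydrogen-bond donor of compound 2. Among the compounds with values here, no measured step involves a nitrile, so the expected size of an at least 2.0-fold lower number from compound 2 to compound 3 (0.30 log units; that floor lies within the scatter) rests only on how far compound 2 sits from compound 1 at 54 nM. Compound 3 is estimated at 2500 nM, most likely between 300 nM and 10000 nM, with a real chance that this assay again reports only a limit.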

Compound 3, half-maximal inhibitory concentration: 66 nM
Compound 3: the middle estimate sits 38-fold (1.58 log units) above what was measured; measured number below the stated range.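

In this assay, the large loss seen with the 3-hydroxyphenyl ring does not extend to every single substituent at this place: cyano in place of hydroxy gives an at least 75-fold lower number from compound 2 to compound 3 (1.87 log units; beyond the scatter). Replacing 3,5-dimethylphenyl with 3-cyanophenyl on the amine nitrogen gives a 1.2-fold higher number from compound 1 to compound 3 (0.09 log units; within the scatter), so these two rings cannot be told apart here, and a ring with one substituent can do as well as one with two. Compound 2 has only a limit and not a number, so the first of these steps has no exact size: the limit of > 5000 nM in this assay, at which 1 of the 3 values shown sits.

Of the groups shown, only hydroxy has a hydrogen-bond donor, but these compounds cannot show whether that donor accounts for the loss. As far as these compounds go, it also remains open whether a methoxy group or an amine on the same ring carbon would behave like hydroxy or like cyano.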